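The source may report more compounds than this note shows. Statements on the series, on what has been measured and on what is new or still open speak of the compounds shown alone.

Working notes on the series. Compound 1 `Cc1cc(Cc2ccccc2)c(=O)n(CC(=O)Nc2ccc(Br)cc2)n1` and compound 2 `Cc1cc(Cc2ccoc2)c(=O)n(CC(=O)Nc2ccc(Br)cc2)n1` share one core and differ only where furan-3-yl replaces phenyl on a saturated chain carbon bound to an aromatic carbon. In a functional assay on HL-60 cells (Homo sapiens), read by calcium flux (on this read-out higher numbers stand for an effect only at larger amounts of compound and lower numbers for an effect already at smaller amounts), compound 1 gives only a limit of > 50000 nM. In this assay compound 2 likewise gives only a limit, > 50000 nM, so compound 2 stands at the limit of what this assay resolves. The step that the two limits leave unreadable from compound 1 to compound 2 is unreadable, since (the limit of > 50000 nM in this assay, at which 2 of the 2 values shown sit). Compound 3 `Cc1cc(Cc2cccc3ccccc23)c(=O)n(CC(=O)Nc2ccc(Br)cc2)n1` carries naphthalen-1-yl in place of furan-3-yl on a saturated chain carbon bound to an aromatic carbon. Within the data shown here, no measured step bears on this change, so its size is open. The step to compound 3 is expected as a step that the limit leaves unreadable from compound 2 to compound 3. Compound 3 is estimated at 60000 nM, between 15000 nM and 200000 nM, most likely again a limit.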

Compound 3, half-maximal effective concentration: > 50000 nM
Compound 3 was reported as a limit; the forecaster's own chance of this, stated with the estimate: 70%; the middle value lies beyond the limit too.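

Among these compounds, no step among compound 1, compound 2 and compound 3 can be read, since each gives only a limit: the limit of > 50000 nM in this assay, at which 3 of the 3 values shown sit. The compounds shown leave open how phenyl, furan-3-yl and naphthalen-1-yl compare, and which change to the shared core would give a readable value in this assay.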